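Swapping the Aryl Group on the Double-Bonded Chain

The source may report more compounds than this note shows. Statements on the series, on what has been measured and on what is new or still open speak of the compounds shown alone.

The series is tested in a functional assay on PC-3 cells (Homo sapiens) for cytotoxicity, read by MTT assay; on this read-out higher numbers stand for weaker inhibition and lower numbers for stronger inhibition. Compound 1 `COc1cccc(/C=C/C(=O)c2sc(Nc3ccc(Cl)cc3)nc2C)c1` gives only a limit in this assay, > 25000 nM. Compound 2 `COc1cccc(/C=C/C(=O)c2sc(Nc3ccccc3)nc2C)c1` likewise reaches only a limit, > 25000 nM. Compound 3 `COc1cccc(/C=C/C(=O)c2sc(Nc3ccccc3C)nc2C)c1` also returns a limit, > 25000 nM. All three sit at the limit of > 25000 nM in this assay, at which 3 of the 3 values shown sit, so the steps a step that the two limits leave unreadable from compound 1 to compound 2, a step that the two limits leave unreadable from compound 1 to compound 3 and a step that the two limits leave unreadable from compound 2 to compound 3 cannot be sized. Compound 4 `Cc1nc(Nc2ccccc2)sc1C(=O)/C=C/c1ccccc1Cl` differs from compound 2 by 2-chlorophenyl in place of 3-methoxyphenyl on a double-bonded chain carbon bound to a double-bonded chain carbon. Within the data shown here, none of the measured steps touches this part of the structure, and none has a readable size, so there is no basis to expect compound 4 to move beyond the scatter away from where compound 2 stands. Compound 4 is therefore expected to sit near the same limit, with an estimated step that the limit leaves unreadable from compound 2 to compound 4 and an estimated value of 30000 nM, between 8000 nM and 100000 nM.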

Compound 4, half-maximal inhibitory concentration: > 25000 nM
Compound 4: no number, only a limit; the forecaster's own chance of this, stated with the estimate: 75%; the middle value lies beyond the limit too.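

Compound 2 and compound 4 both give only a limit, so the step between them cannot be read. The compounds shown leave open whether either swap changes activity at all in this assay.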